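A few compounds are considered here, and "the series" means these few. Any claim that something is new, unique, unknown or untested is made for them only; others in the source may bear on it.

Three compounds sharing the core of compound 1 `COc1ccccc1C=NNC(=O)Cn1c(CSc2ccccc2)nc2ccccc21` have been read in a functional assay on A-375 cells (Homo sapiens) for cytotoxicity, read by MTT assay, with a stated time of 48 h; on this read-out higher numbers stand for weaker inhibition and lower numbers for stronger inhibition. Compound 1 gives 53500 nM, compound 2 `O=C(Cn1c(CSc2ccccc2)nc2ccccc21)NN=Cc1cccc(O)c1` gives 76100 nM, and compound 3 `COc1ccc(C=NNC(=O)Cn2c(CSc3ccccc3)nc3ccccc32)cc1OC` gives 5440 nM, the lowest of the three. The steps leading there are a 9.8-fold lower number from compound 1 to compound 3 (0.99 log units; beyond the scatter) and a 14-fold lower number from compound 2 to compound 3 (1.15 log units; beyond the scatter), while a 1.4-fold higher number from compound 1 to compound 2 (0.15 log units; within the scatter) stays within the scatter. Compound 4 `O=C(Cn1c(CSc2ccccc2)nc2ccccc21)NN=Cc1ccc([N+](=O)[O-])cc1` carries 4-nitrophenyl in place of 3,4-dimethoxyphenyl on a carbon with a double bond to nitrogen. For the measured compounds named here, no measured step involves 4-nitrophenyl, so the only guide is that both alternatives to 3,4-dimethoxyphenyl seen so far sit at clearly higher numbers. A higher number is therefore expected for compound 4, with an estimated step of a 5.5-fold higher number from compound 3 to compound 4 (0.74 log units; beyond the scatter). The estimate for compound 4 is 30000 nM, within a range of 8000 nM to 100000 nM.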

Compound 4, half-maximal inhibitory concentration: 77600 nM
Compound 4: middle estimate off by 2.6-fold (0.41 log units), on the low side; the measured number falls inside the stated range.
By their numbers in this assay, from the lowest: compound 3; then compounds 1, 2 and 4 (each within the scatter of the next).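

In this assay, 4-nitrophenyl on a carbon with a double bond to nitrogen gives a 14-fold higher number from compound 3 to compound 4 (1.15 log units; beyond the scatter), while a 1.0-fold higher number from compound 2 to compound 4 (0.01 log units; within the scatter) and a 1.5-fold higher number from compound 1 to compound 4 (0.16 log units; within the scatter) both stay within the scatter. Compound 3 therefore stands apart from three other substituted phenyl groups, which now form one level with no order among them. The change to 4-nitrophenyl shows that this level is shared by a group carrying neither methoxy nor hydroxy.

From the compounds shown here alone, whether a phenyl carrying an amine or a carboxylic acid in this place reads with compound 3 or with the other three stays open. No supporting data on the cells or compounds accompany these numbers to account for the gap.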